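Sulfonamide amine swap on the tolyl series

This account rests on a few compounds, and the source may have more. Where it says the series, first, only, none or still open, it means among the compounds named here.

Of the compounds shown here, three of one shared core have been measured in an assay on Sf9 cells for inhibition of serine/threonine-protein kinase 4 (Homo sapiens), read by luminescence and ADP-Glo, with a stated time of 1 h, in the presence of a further agent that is not named here; a higher number here means a weaker inhibitor, a lower number a stronger inhibitor. Compound 1 `CN1C(=O)C(c2c(F)cccc2F)N(C)c2nc(Nc3ccc(S(=O)(=O)NCC4CC4)cc3)ncc21` gives 79 nM. Compound 2 `CCNS(=O)(=O)c1ccc(Nc2ncc3c(n2)N(C)C(c2ccccc2C)C(=O)N3C)cc1` gives 119 nM. Compound 3 `Cc1ccccc1C1C(=O)N(C)c2cnc(Nc3ccc(S(=O)(=O)N(C)C)cc3)nc2N1C` gives 219 nM, the high end of the three numbers; the gap to compound 1 is beyond the scatter, while the gap to compound 2 is within it, as the single-place step shows: a 1.8-fold higher number from compound 2 to compound 3 (0.26 log units; within the scatter).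

Compound 4 `Cc1ccccc1C1C(=O)N(C)c2cnc(Nc3ccc(S(=O)(=O)NCC4CC4)cc3)nc2N1C` is yet to be measured. It differs from compound 3 in one place: (cyclopropylmethyl)amino in place of dimethylamino on a sulfonyl sulfur. Going by the values given here, the one measured step on this sulfonyl sulfur, a 1.8-fold higher number from compound 2 to compound 3 (0.26 log units; within the scatter), exchanged an alkylamino for dimethylamino and stayed within the scatter. Compound 1 carries the same (cyclopropylmethyl)sulfamoyl as compound 4 but a different aryl group on the core, so its number gives only a loose pointer. A small step towards a lower number is therefore expected, a 1.8-fold lower number from compound 3 to compound 4 (0.26 log units; within the scatter), probably within the scatter. Compound 4 is estimated at 120 nM, with a range from 50 nM to 300 nM.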

Compound 4, half-maximal inhibitory concentration: 60 nM
The estimate for compound 4 lay 2.0-fold (0.30 log units) above the measured number; low and high end bracket the measured number.
By their numbers in this assay, from the lowest: compounds 4, 1, 2 and 3 (each within the scatter of the next, the first and the last beyond it).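

In this assay, the sulfonyl sulfur position now shows a change beyond the scatter (a 3.7-fold lower number from compound 3 to compound 4 (0.56 log units; beyond the scatter)) for (cyclopropylmethyl)amino in place of dimethylamino, whereas the earlier step on this sulfur (a 1.8-fold higher number from compound 2 to compound 3 (0.26 log units; within the scatter)) stayed within it. Cyclopropyl in place of methyl on the saturated chain carbon bound to the sulfonamide nitrogen stays within the scatter (a 2.0-fold lower number from compound 2 to compound 4 (0.30 log units; within the scatter)), as does 2-methylphenyl in place of 2,6-difluorophenyl on the saturated ring carbon (a 1.3-fold lower number from compound 1 to compound 4 (0.12 log units; within the scatter)), so neither change separates its pair. No measurement at hand accounts for the step from dimethylamino to (cyclopropylmethyl)amino.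

As far as these compounds go, it remains open whether that step depends on the hydrogen-bond donor of the secondary sulfonamide or on the cyclopropylmethyl group itself. A methyl(cyclopropylmethyl)amino group on the sulfonyl sulfur would separate the two, and a plain amino group or a longer chain such as butylamino would show how far the position extends.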